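A few compounds are considered here, and "the series" means these few. Any claim that something is new, unique, unknown or untested is made for them only; others in the source may bear on it.

Working notes on the series. Compound 1 `COc1cc2nc(N3CCN(C(=O)c4ccc(Br)o4)[C@H]4CCCC[C@H]43)nc(N)c2cc1OC` is the reference point of the set: in an assay on CHO cells for displacement of a labelled ligand from Alpha-1D adrenergic receptor (Homo sapiens) (a higher number here means a weaker inhibitor, a lower number a stronger inhibitor), compound 1 gives 1.55 nM. Compound 2 `COc1cc2nc(N3CCN(C(=O)c4ccc(C(C)=O)o4)[C@H]4CCCC[C@H]43)nc(N)c2cc1OC` differs at the aromatic carbon only, and in this assay compound 2 gives 7.41 nM; the step is a 4.8-fold higher number from compound 1 to compound 2 (0.68 log units; beyond the scatter). Among the measured compounds shown here, compound 3 `COc1cc2nc(N3CCN(C(=O)c4ccccn4)[C@H]4CCCC[C@H]43)nc(N)c2cc1OC` carries the pyridin-2-yl on the carbonyl carbon, and in this assay compound 3 gives 26.9 nM, the highest number of the three measured so far; the steps to it are a 17-fold higher number from compound 1 to compound 3 (1.24 log units; beyond the scatter) and a 3.6-fold higher number from compound 2 to compound 3 (0.56 log units; beyond the scatter).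

Compound 4 `COc1cc2nc(N3CCN(C(=O)c4ccccc4)[C@H]4CCCC[C@H]43)nc(N)c2cc1OC` is the next member. The change from compound 3 is phenyl in place of pyridin-2-yl on a carbonyl carbon. For the measured compounds named here, both measured steps that end at compound 3 swap a five-membered furan-type ring for the pyridin-2-yl; neither exchanges the pyridin-2-yl for phenyl, so no measured step bears directly on this change. With nothing in the series to set a direction, the step of a 1.3-fold lower number from compound 3 to compound 4 (0.13 log units; within the scatter) is expected to stay within the scatter. Compound 4 is therefore estimated at 20 nM, in the range 7 nM to 70 nM.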

Compound 4, inhibition constant: 3.24 nM
The estimate for compound 4 lay 6.2-fold (0.79 log units) above the measured number, and the stated range ends above it.
By their numbers in this assay, from the lowest: compound 1; then compound 4; then compound 2; then compound 3.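

At the carbonyl carbon, the aromatic ring is not interchangeable: with the heavy-atom count unchanged, replacing pyridin-2-yl with phenyl, one ring nitrogen giving way to carbon, gives an 8.3-fold lower number from compound 3 to compound 4 (0.92 log units; beyond the scatter) in this assay and is the largest change at this place apart from the step between the bromofuran and the pyridine. The unsubstituted phenyl also falls among the furan amides, with a 2.3-fold lower number from compound 2 to compound 4 (0.36 log units; beyond the scatter) and a 2.1-fold higher number from compound 1 to compound 4 (0.32 log units; beyond the scatter), both beyond the scatter, so the pyridin-2-yl amide compound 3 alone stands apart at the weak end. Nothing measured here explains the gap between the two six-membered rings.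

The compounds shown leave open whether the difference between bromo and acetyl on the furan carries over to the phenyl. They also leave open how an amine or a carboxylic acid on that phenyl would read in this assay.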